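The source may hold more compounds than are shown below. What is called first, only, known or untested is meant among the compounds shown, and "the series" means these compounds.

Compound 1 `Cc1cc(Nc2cc(-c3ccccc3)[nH]n2)n2nc(SCc3ccccc3Br)nc2n1`: 3020 nM
Compound 2 `Cc1ccc(CSc2nc3nc(C)cc(Nc4cc(-c5ccccc5)[nH]n4)n3n2)cc1`: 7290 nM

Among the measured compounds shown here, in a functional assay on MCF7 cells (Homo sapiens) for inhibition, read by MTT assay, with a stated time of 72 h (a lower number here means a stronger inhibitor, a higher number a weaker inhibitor), compound 2 gives 7290 nM and holds the higher of the two numbers so far. Compound 3 `Cc1cc(Nc2cc(-c3ccccc3)[nH]n2)n2ncnc2n1` carries hydrogen in place of (4-methylbenzyl)sulfanyl on an aromatic carbon. For the measured compounds named here, the only measured step is a 2.4-fold higher number from compound 1 to compound 2 (0.38 log units; beyond the scatter) and it was modest, exchanging 2-bromophenyl for 4-methylphenyl within the group that now leaves. Going by the values given here, no measurement yet covers loss of the whole group. A move toward a higher number is expected, and the estimated change is a 2.1-fold higher number from compound 2 to compound 3 (0.31 log units; beyond the scatter) in this assay overall. Compound 3 is expected at 15000 nM with an estimated range from 4500 nM to 50000 nM.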

Compound 3, half-maximal inhibitory concentration: > 50000 nM
Compound 3 gave a limit, no number; the forecaster's own chance of this, stated with the estimate: 20%; middle value at least 3.3-fold (0.52 log units) away from the limit.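

In this assay, hydrogen in place of (4-methylbenzyl)sulfanyl on the aromatic carbon gives an at least 6.8-fold higher number from compound 2 to compound 3 (0.83 log units; beyond the scatter), and hydrogen in place of (2-bromobenzyl)sulfanyl gives an at least 16-fold higher number from compound 1 to compound 3 (1.21 log units; beyond the scatter). Losing the whole group thus counts for more at this position than the exchange within it, which gave a 2.4-fold higher number from compound 1 to compound 2 (0.38 log units; beyond the scatter). The reading for compound 3 is a limit, not a number: the limit of > 50000 nM in this assay, at which 1 of the 3 values shown sits.

As far as these compounds go, how far compound 3 lies past that limit stays open. So does whether a methylsulfanyl group or an amine on this carbon would keep a measurable value, and with it whether the sulfur or the benzene ring matters more.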